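The compounds below may be only part of what the source reports. "The series", "measured", "known", "first", "only" and "open" are said of these compounds alone.

Working notes on the series. Compound 1 `CC(C)=CCC1Cc2c(OCc3ccccc3)cc(=O)n(CCCO)c2CC1(C)C` is the reference of the set: in a functional assay on PANC-1 cells (Homo sapiens) for inhibition, read by MTT assay, with a stated time of 24 h, tested at 10 uM (a lower number here means less inhibition, a higher number more inhibition at the concentration tested (going by the name of the read-out)), compound 1 gives 11.1%. Compound 2 `CC(C)=CCC1Cc2c(OCCCOc3ccc(Cl)cc3)cc(=O)n(CCCO)c2CC1(C)C` gives 0% in this assay, a drop recorded as a number 11.1 percentage points lower from compound 1 to compound 2 (beyond the scatter). Compound 3 `COc1ccccc1NC(=O)Oc1cc(=O)n(CCCO)c2c1CC(CC=C(C)C)C(C)(C)C2` gives 0% in this assay. Compound 3 stands level with compound 2, the two together being the lowest of the three numbers; the relevant steps are a number 11.1 percentage points lower from compound 1 to compound 3 (beyond the scatter) and no change at the digits printed from compound 2 to compound 3 (within the scatter). Compound 4 `CC(C)=CCC1Cc2c(OC(=O)Nc3ccc(Cl)cc3)cc(=O)n(CCCO)c2CC1(C)C` is not yet measured. It differs from compound 3 by 4-chlorophenyl in place of 2-methoxyphenyl on an amide-type nitrogen. Within the data shown here, no measured step changes the group on the amide-type nitrogen, so none bears directly on this move; the two steps that reach compound 3, both ending at the floor of the read-out, are the only guide, and both were modest. The expected step of a number 2 percentage points higher from compound 3 to compound 4 (within the scatter) is therefore none beyond the scatter. Compound 4 is estimated at 2% in this assay, with a range from 0% to 14%.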

Compound 4, a percentage reported as inhibition, at one concentration (the size of the read-out at that concentration, not a potency): 0%
Beside the measured number, compound 4's estimate is 2 percentage points above it; low and high end bracket the measured number.
By their numbers in this assay, from the lowest: compounds 2, 3 and 4 (each within the scatter of the next); then compound 1.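

In this assay, among these compounds, the change of 2-methoxyphenyl to 4-chlorophenyl on an amide-type nitrogen, the first measured change at this position, gives no change at the digits printed from compound 3 to compound 4 (within the scatter) and leaves the number at the floor of the read-out. The (4-chlorophenyl)carbamoyl group on an oxygen on an aromatic ring shows no change at the digits printed from compound 2 to compound 4 (within the scatter) when it replaces 3-(4-chlorophenoxy)propyl and a number 11.1 percentage points lower from compound 1 to compound 4 (beyond the scatter) when it replaces benzyl, so a second carbamoyl sits at the floor and only compound 1 stands off it. No measurement at hand offers an explanation for these results.

With three of the four numbers at the floor, the effect of the group on the amide-type nitrogen cannot be ranked. On these data alone, whether an amine or a carboxylic acid in place of the chlorine, or a longer alkyl chain in place of the aryl ring, would lift the number in this assay remains open.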